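This account rests on a few compounds, and the source may have more. Where it says the series, first, only, none or still open, it means among the compounds named here.

Compound 1 `COc1ccc(C(=O)c2cc(OC)c(OC)c(OC)c2)cc1NC(=O)/C=C/c1ccc(F)cc1` gives 400 nM in a functional assay on B16 cells (Mus musculus) for cytotoxicity, read by MTT assay, with a stated time of 72 h; on this read-out higher numbers stand for weaker inhibition and lower numbers for stronger inhibition; compound 2 `COc1ccc(C(=O)c2cc(OC)c(OC)c(OC)c2)cc1NC(=O)/C=C/c1ccc(C(F)(F)F)cc1` gives 100 nM in this assay; compound 3 `COc1cc(/C=C/C(=O)Nc2cc(C(=O)c3cc(OC)c(OC)c(OC)c3)ccc2OC)ccc1F` gives 16300 nM in this assay.

Among these three numbers compound 1 stands second highest: the change a 4.0-fold lower number from compound 1 to compound 2 (0.60 log units; beyond the scatter), while a 41-fold higher number from compound 1 to compound 3 (1.61 log units; beyond the scatter). Compound 4 `COc1cc(C(=O)c2cc(OC)c(OC)c(OC)c2)cc(NC(=O)/C=C/c2ccc(F)cc2)c1OC` differs from compound 1 by methoxy in place of hydrogen on an aromatic carbon. For the measured compounds named here, the only measured step of the same kind is a 41-fold higher number from compound 1 to compound 3 (1.61 log units; beyond the scatter), yet that methoxy entered on the other aromatic ring of the molecule, so how far it carries over to a methoxy on the core ring is uncertain. A weakening is still the expectation, so compound 4 is estimated at 3000 nM, in the range 600 nM to 15000 nM, meaning an expected step of a 7.5-fold higher number from compound 1 to compound 4 (0.88 log units; beyond the scatter).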

Compound 4, half-maximal inhibitory concentration: 900 nM
The estimate for compound 4 lay 3.3-fold (0.52 log units) above the measured number, and the stated range covers the measured number.
By their numbers in this assay, from the lowest: compound 2; then compound 1; then compound 4; then compound 3.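

Placing methoxy in place of hydrogen on the shared core, ortho to a methoxy group, costs little (a 2.3-fold higher number from compound 1 to compound 4 (0.35 log units; beyond the scatter)), whereas the same swap on the other aromatic ring costs far more (a 41-fold higher number from compound 1 to compound 3 (1.61 log units; beyond the scatter)). The effect of this change in this assay therefore depends strongly on where it is made, and this position accepts the added group with only a modest loss. Nothing shown here explains that difference.

As far as these compounds go, whether a hydroxyl, an amine or a longer ethoxy chain would be accepted at this position remains open. So does whether this methoxy would cost the same alongside the trifluoromethyl group of compound 2.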